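A few compounds are considered here, and "the series" means these few. Any claim that something is new, unique, unknown or untested is made for them only; others in the source may bear on it.

Measured compounds:
- compound 1, `O=C(O)c1cc(-c2cccc(COc3ccc4c(c3)CN(Cc3ccc(C(F)(F)F)cc3)C4=O)c2)ccc1Cl`: 100%
- compound 2, `O=C(O)c1cc(-c2cccc(COc3ccc4c(c3)CN(C3CCCCC3)C4=O)c2)ccc1Cl`: 99%

In an ADME assay on a cell-free system (plasma, Rattus norvegicus), with a stated time of 60 min (a lower number here means that less of the compound is left, a higher number that more of the compound is left), compound 1 gives 100% and compound 2 gives 99%. Compound 2 thus holds the lower of the two numbers, but only by a number 1 percentage points lower from compound 1 to compound 2 (within the scatter), so the two compounds cannot be told apart on this assay. The step into compound 2 replaced 4-(trifluoromethyl)benzyl with cyclohexyl on the amide-type nitrogen in the ring of the shared core, and the number did not move beyond the scatter.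

Compound 3, `O=C(O)c1cc(-c2cccc(COc3ccc4c(c3)CN(c3ccccc3)C4=O)c2)ccc1Cl`, is not yet measured in this assay. It differs from compound 2 by phenyl in place of cyclohexyl on an amide-type nitrogen in a ring. Among the measured compounds shown here, the only measured step that bears on changes at this position is the one from compound 1 to compound 2, which was small, so a large move is not expected here either. The step from compound 2 to compound 3 is expected to be about a number 2 percentage points lower from compound 2 to compound 3 (within the scatter), which is no change beyond the scatter. For compound 3 the estimated value in this assay is therefore 97%, with a range from 85% to 100%.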

Compound 3, percent of the compound remaining: 100%
For compound 3 the middle estimate is 3 percentage points below the measured one, within the range that was stated.
By their numbers in this assay, from the lowest: compounds 2, 1 and 3 (each within the scatter of the next).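

Exchanging cyclohexyl for phenyl on the amide-type nitrogen in a ring keeps the count of six carbon heavy atoms but turns a non-aromatic ring into an aromatic one, and it gives a number 1 percentage points higher from compound 2 to compound 3 (within the scatter) in this assay, while phenyl in place of 4-(trifluoromethyl)benzyl gives no change at the digits printed from compound 1 to compound 3 (within the scatter). The earlier pair had compared only a substituted benzyl group with a non-aromatic ring, so the new result adds an aromatic ring of carbon only at this position, and all three groups now stand within the scatter of one another in this assay. No measurement at hand speaks to why this position tolerates these exchanges so evenly.

As far as these compounds go, all three compounds carry a group made of carbon, apart from the trifluoromethyl of compound 1, so it remains open whether an amine, such as a piperidine ring, or a longer alkyl chain on this nitrogen would stay within the scatter in this assay. From the compounds shown here alone, it is equally open whether an ester in place of the carboxylic acid on the shared core would leave the number where it stands.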